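Series notes: a group added on the five-membered ring carbon

The source may report more compounds than this note shows. Statements on the series, on what has been measured and on what is new or still open speak of the compounds shown alone.

Measured compounds:
- compound 1, `Cc1cn2cccc(OCc3ccccc3)c2n1`, in a functional assay on the whole organism (stomach) for inhibition, with Canis familiaris (Canis lupus familiaris) as the target, at a dose of 5 mg/kg by the intravenous route; a higher number here means a stronger effect of the compound at the dose given, a lower number a weaker effect: 70%
- compound 2, `Cc1nc2c(OCc3ccccc3)cccn2c1CCC#N`, in this assay: 20%
- compound 3, `Cc1nc2c(OCc3ccccc3)cccn2c1C[S+](C)[O-]`, not yet measured

Compound 1 stands highest of the two numbers in hand; its nearest neighbour is compound 2, with a number 50 percentage points lower from compound 1 to compound 2 (beyond the scatter). That step is the only one that bears on the change now considered, since compound 3 differs from compound 1 by a group of 4 heavy atoms (2 carbon, 1 oxygen, 1 sulfur; no ring) in place of a hydrogen atom, on an aromatic carbon, the same aromatic carbon that carries 2-cyanoethyl in compound 2. Within the data shown here, the one measured step at this place was large and beyond the scatter, downward. A step of the same direction is therefore expected for compound 3 in this assay, with the size uncertain because only a number 50 percentage points lower from compound 1 to compound 2 (beyond the scatter) informs it and the entering group differs. Compound 3 is expected to give 25%, within 5% to 50%, meaning an estimated a number 45 percentage points lower from compound 1 to compound 3 (beyond the scatter).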

Compound 3, a percentage reported as inhibition, in the whole organism at one dose (the size of the read-out at that dose, not a potency): 18%
Compound 3: middle estimate off by 7 percentage points, on the high side; measured number inside the range.
By their numbers in this assay, from the lowest: compounds 3 and 2 (each within the scatter of the next); then compound 1.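

In this assay, a second group on this aromatic carbon, the 4-heavy-atom group with sulfur and oxygen and no ring, also comes with a large loss (a number 52 percentage points lower from compound 1 to compound 3 (beyond the scatter)). The two substituted compounds cannot be told apart (a number 2 percentage points lower from compound 2 to compound 3 (within the scatter)), so the loss at this position is no longer tied to 2-cyanoethyl alone and holds for two groups with different heavy atoms. Nothing at hand accounts for this loss.

Among these compounds, whether any group on this carbon keeps the level of compound 1 remains open, since only two groups can be compared here, and a lone methyl or a hydroxymethyl would test this. Also open, from the compounds shown here alone, is how a chain ending in an amine or a carboxylic acid would read in this assay.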